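This account rests on a few compounds, and the source may have more. Where it says the series, first, only, none or still open, it means among the compounds named here.

Compound 1 `CNC(=O)[C@@]12C[C@@H]1[C@@H](n1cnc3c(NC)nc(C#Cc4ccc(Cl)cc4)nc31)[C@H](O)[C@@H]2O`: in an assay on CHO cells for displacement of a labelled ligand from adenosine receptor A1 (Homo sapiens), read by scintillation counting, with a stated time of 60 min, tested at 10 uM (on this read-out higher numbers stand for more inhibition at the one concentration tested (going by the name of the read-out) and lower numbers for less inhibition), compound 1 gives 13%.
Compound 2 `CNC(=O)[C@@]12C[C@@H]1[C@@H](n1cnc3c(NC)nc(C#Cc4ccc(CO)cc4)nc31)[C@H](O)[C@@H]2O`: in this assay compound 2 gives 16%.

Compound 1 stands at the lower of the two numbers, but the step of a number 3 percentage points higher from compound 1 to compound 2 (within the scatter) lies within the scatter, so the two compounds cannot be told apart. Compound 3 `CNC(=O)[C@@]12C[C@@H]1[C@@H](n1cnc3c(NC)nc(C#CC4CC4)nc31)[C@H](O)[C@@H]2O` differs from compound 1 by cyclopropyl in place of 4-chlorophenyl on a triple-bonded carbon. For the measured compounds named here, no measured step touches this change: the one step available, a number 3 percentage points higher from compound 1 to compound 2 (within the scatter), concerns another group and is itself within the scatter. The step of a number 1 percentage points lower from compound 1 to compound 3 (within the scatter) is therefore expected to stay within the scatter. Compound 3 is estimated at 12%, with a range from 0% to 30%.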

Compound 3, a percentage reported as inhibition, at one concentration (the size of the read-out at that concentration, not a potency): 38%
Compound 3: the middle estimate sits 26 percentage points below what was measured, and the stated range ends below it.
By their numbers in this assay, from the lowest: compounds 1 and 2 (each within the scatter of the next); then compound 3.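

Exchanging the whole ring on the triple-bonded carbon moves the read-out in this assay: cyclopropyl in place of 4-chlorophenyl gives a number 25 percentage points higher from compound 1 to compound 3 (beyond the scatter), and cyclopropyl in place of 4-(hydroxymethyl)phenyl gives a number 22 percentage points higher from compound 2 to compound 3 (beyond the scatter). The earlier pair differed only in the group carried on the aromatic ring and showed no change beyond the scatter, whereas this position responds once that ring itself is replaced. As far as these compounds go, whether a cyclobutyl ring, a longer carbon chain or a chain ending in an amine on the triple-bonded carbon would raise the number further stays open. Nothing measured here gives a reason for the rise.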